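A few compounds are considered here, and "the series" means these few. Any claim that something is new, unique, unknown or untested is made for them only; others in the source may bear on it.

Compound 1 `COC(=O)C(Cc1cccc(C(=N)N)c1)C(/C=C/c1ccccc1)NC(=O)c1ccc(-c2ccc(C)cc2)cc1` gives 2800 nM in an assay on isolated protein (Oryctolagus cuniculus) for inhibition of Trypsin (Homo sapiens); on this read-out higher numbers stand for weaker inhibition and lower numbers for stronger inhibition. Going by the values given here, the only other number known is that of compound 2 `CCOc1ccccc1-c1ccc(C(=O)NC(/C=C/c2ccccc2)C(Cc2cccc(C(=N)N)c2)C(=O)OC)cc1`, which gives 1800 nM; a 1.6-fold lower number from compound 1 to compound 2 (0.19 log units; within the scatter). Compound 3 `CCOc1cccc(-c2ccc(C(=O)NC(/C=C/c3ccccc3)C(Cc3cccc(C(=N)N)c3)C(=O)OC)cc2)c1` remains to be measured; (3-ethoxyphenyl in place of 4-methylphenyl on an aromatic carbon). Among the compounds with values here, the one measured step that bears on it also replaced 4-methylphenyl with an ethoxyphenyl group, and it stayed within the scatter. For compound 3, therefore, no step beyond the scatter is expected in this assay, and the expected step is a 1.3-fold lower number from compound 1 to compound 3 (0.10 log units; within the scatter). Compound 3 is estimated at 2200 nM, in a range from 800 nM to 6000 nM.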

Compound 3, half-maximal inhibitory concentration: 3600 nM
For compound 3 the middle estimate is 1.6-fold (0.21 log units) below the measured one; the measured number falls inside the stated range.
By their numbers in this assay, from the lowest: compounds 2, 1 and 3 (each within the scatter of the next).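

With 3-ethoxyphenyl in place of 4-methylphenyl, the result is a 1.3-fold higher number from compound 1 to compound 3 (0.11 log units; within the scatter) in this assay. Moving to 3-ethoxyphenyl from 2-ethoxyphenyl gives a 2.0-fold higher number from compound 2 to compound 3 (0.30 log units; within the scatter), so at this aromatic carbon neither ethoxyphenyl group separates from 4-methylphenyl or from the other, and the change of ethoxy placement adds no step beyond the scatter. Going by these compounds alone, no evidence on these compounds bears on the result.

Still open, on these data alone, is whether an aminomethyl group or a carboxylic acid on this phenyl ring would give a step beyond the scatter.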